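The source may report more compounds than this note shows. Statements on the series, on what has been measured and on what is new or still open speak of the compounds shown alone.

Measured compounds:
Compound 1, `CC(=O)N1CCC[C@H]1C(=O)OCC(F)F`, gives 0.02 in a physicochemical assay for lipophilicity, read by NMR; on this read-out higher numbers stand for higher lipophilicity and lower numbers for lower lipophilicity.
Compound 2, `OCCC(F)(F)C(F)F`, gives 0.66 in this assay.
Compound 3, `CC(=O)N1CCC[C@H]1C(=O)OCCF`, gives -0.43 in this assay.

Compound 2 stands highest of the three; compound 1 lies beyond the scatter below it and compound 3 further below still. Compound 1 and compound 3 share one core and differ in one place: hydrogen in place of fluoro on a saturated chain carbon bound to a fluorine atom and a saturated chain carbon. That change produced a number 0.45 log units lower from compound 1 to compound 3 (beyond the scatter). The difference between the core of compound 1 and the core of compound 2 is not broken down here.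

Compound 4, `OCCC(F)C(F)F`, is not yet measured. It stands to compound 2 as compound 3 stands to compound 1: hydrogen in place of fluoro on a saturated chain carbon bound to a fluorine atom and two saturated chain carbons. The surroundings are not identical, since in compound 1 the carbon that loses its fluoro is bound to a fluorine atom and a saturated chain carbon, whereas in compound 2 it is bound to a fluorine atom and two saturated chain carbons; the two changes are therefore the same kind of change, not the same one. Because the earlier change gave a number 0.45 log units lower from compound 1 to compound 3 (beyond the scatter), a drop of similar size is expected here, so that compound 4 is estimated to lie at 0.2, between -0.1 and 0.5. For the measured compounds named here, the step expected from compound 2 to compound 4 is a number 0.46 log units lower from compound 2 to compound 4 (beyond the scatter), resting on the single earlier step alone.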

Compound 4, partition coefficient: 0.29
The estimate for compound 4 lay 0.09 log units below the measured number, within the range that was stated.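

In this assay, hydrogen in place of fluoro on the core of compound 2 gave a number 0.37 log units lower from compound 2 to compound 4 (beyond the scatter), while the same kind of change on the core of compound 1 had given a number 0.45 log units lower from compound 1 to compound 3 (beyond the scatter); both steps run downward and both are printed as beyond the scatter. This shows that the direction of the change carried over between these two cores, even though the carbon losing its fluoro is bound to a fluorine atom and two saturated chain carbons in one case and to a fluorine atom and a saturated chain carbon in the other. For the compounds shown here, it does not establish a general rule, as this is only two pairs of compounds in differing surroundings, and nothing available bears on why the number falls in either pair.

The compounds shown leave open whether the same change would run the same way on a longer chain, or on a core carrying an amine or a carboxylic acid. They also leave open how it would behave on a carbon of a trifluoromethyl group, where the fluoro would leave a different set of neighbouring atoms.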